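Taking the carbonyl group off compound 2

The source may report more compounds than this note shows. Statements on the series, on what has been measured and on what is new or still open speak of the compounds shown alone.

Measured so far:
Compound 1 `COc1ccc(CNc2cc(OC)c(OC)c(OC)c2)cc1[N+](=O)[O-]` gives 18200 nM
Compound 2 `C/C=C/C(=O)N(Cc1ccc(OC)c(N)c1)c1cc(OC)c(OC)c(OC)c1` gives 300 nM

In a functional assay on HCT-116 cells (Homo sapiens) for inhibition, read by MTT assay, with a stated time of 48 h (a lower number here means a stronger inhibitor, a higher number a weaker inhibitor), compound 2 stands lowest of the two at 300 nM against compound 1 at 18200 nM on the same read-out, a gap beyond the usual scatter.

Compound 3 `COc1ccc(CNc2cc(OC)c(OC)c(OC)c2)cc1N` has not yet been measured. It differs from compound 2 by a single change hydrogen in place of (prop-1-en-1-yl)carbonyl on a nitrogen on an aromatic ring with hydrogen in place of (prop-1-en-1-yl)carbonyl on a nitrogen on an aromatic ring. Within the data shown here, no measured pair isolates this change, so its size in this assay rests on indirect evidence only. A higher number is expected for compound 3 because compound 1 gives 18200 nM without that group, though a single compound is thin support. The expected change is a 5.0-fold higher number from compound 2 to compound 3 (0.70 log units; beyond the scatter) in the direction of weaker inhibition and beyond the scatter. The estimated value for compound 3 is 1500 nM (expected range 300 nM to 8000 nM).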

Compound 3, half-maximal inhibitory concentration: 8270 nM
Compound 3: the middle estimate sits 5.5-fold (0.74 log units) below what was measured; the measured number lies above the stated range.
By their numbers in this assay, from the lowest: compound 2; then compound 3; then compound 1.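

In this assay, among these compounds, the step of a 28-fold higher number from compound 2 to compound 3 (1.44 log units; beyond the scatter) gives the first direct reading of this change: with hydrogen in place of (prop-1-en-1-yl)carbonyl on a nitrogen on an aromatic ring, the inhibition of compound 2 is largely lost. The other single change now readable, amino in place of nitro on an aromatic carbon, gives a 2.2-fold lower number from compound 1 to compound 3 (0.34 log units; beyond the scatter) and is modest by comparison, so among the two steps in hand the larger one belongs to the (prop-1-en-1-yl)carbonyl group on this nitrogen. No measurement here bears on what lies behind either step.

Among the compounds shown here, only one group on this nitrogen has been set against hydrogen, so it remains open whether the double bond matters or whether a saturated butanoyl chain, a shorter acetyl group or a carbamate would hold the number of compound 2. Going by these compounds, the amino to nitro exchange has also been read only with hydrogen on this nitrogen, and its size with the (prop-1-en-1-yl)carbonyl group in place remains open, as does the effect of a hydroxyl group at that aromatic carbon.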